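Replacing 2-methylpyridin-3-yl with cyclohexyl on a short-lived compound

The compounds below may be only part of what the source reports. "The series", "measured", "known", "first", "only" and "open" are said of these compounds alone.

In an ADME assay on microsomes from liver (Rattus norvegicus) for metabolic stability (on this read-out lower numbers stand for a shorter-lived compound and higher numbers for a longer-lived compound), compound 1 `CC#C[C@@H](Cc1nnn[nH]1)c1ccc(OCc2ccc3scc(-c4cccnc4C)c3c2)cc1` gives 0.183 h. This lies within the usual scatter of compound 3 `CC#C[C@@H](Cc1nnn[nH]1)c1ccc(OCc2cc(Cl)c3scc(-c4ccccc4C)c3c2)cc1`, at 0.117 h, whereas compound 2 `CC#C[C@@H](Cc1nnn[nH]1)c1ccc(OCc2ccc3scc(-c4ccc(OCCCS(C)(=O)=O)cc4C)c3c2)cc1`, at 1.48 h, is clearly longer-lived than compound 1. Compound 4 `CC#C[C@@H](Cc1nnn[nH]1)c1ccc(OCc2ccc3scc(C4CCCCC4)c3c2)cc1` keeps the core of compound 1 but carries cyclohexyl in place of 2-methylpyridin-3-yl on an aromatic carbon. For the measured compounds named here, no measured pair isolates this swap, so the value of compound 1 is the only anchor for the estimate. The expected change is small, slightly downward and within the scatter, an estimated 1.3-fold lower number from compound 1 to compound 4 (0.12 log units; within the scatter). For compound 4, the expected half-life is 0.14 h, with an estimated range of 0.05 h to 0.4 h.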

Compound 4, half-life: 0.767 h
Estimate against measurement, compound 4: 5.5-fold (0.74 log units) below; measured number outside the range, above it.
By their numbers in this assay, from the lowest: compounds 3 and 1 (each within the scatter of the next); then compounds 4 and 2 (each within the scatter of the next).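

At this position, on an aromatic carbon two ring bonds from the ring sulfur, replacing 2-methylpyridin-3-yl with cyclohexyl gives a 4.2-fold higher number from compound 1 to compound 4 (0.62 log units; beyond the scatter) in this assay. The half-life therefore responds to the group placed here, and on the core of compound 1 an aromatic ring at this position is not required for the longer-lived result. No available evidence explains this step. From the compounds shown here alone, whether the gain would hold with a smaller ring such as cyclopentyl, or with a cyclohexyl carrying an amine or a carboxylic acid, remains open.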